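Halogen swap on the anilide ring: chloro to bromo

The source may report more compounds than this note shows. Statements on the series, on what has been measured and on what is new or still open speak of the compounds shown alone.

Measured compounds:
- compound 1 `CN(C)C(=O)c1cc2cnc(Nc3ccc(NC(=O)C4(C(=O)Nc5ccccc5)CC4)cc3)nc2n1C1CCCC1` — in a functional assay on SiHa cells (Homo sapiens) for inhibition, read by CCK-8 assay, with a stated time of 72 h, tested at 1 uM (on this read-out lower numbers stand for less inhibition of growth and higher numbers for more inhibition of growth at the one concentration tested), compound 1 gives 58%
- compound 2 `CN(C)C(=O)c1cc2cnc(Nc3ccc(NC(=O)C4(C(=O)Nc5ccc(Br)cc5)CC4)cc3)nc2n1C1CCCC1` — compound 2 gives 23.2%
- compound 3 `CN(C)C(=O)c1cc2cnc(Nc3ccc(NC(=O)C4(C(=O)Nc5cccc(Cl)c5)CC4)cc3)nc2n1C1CCCC1` — compound 3 gives 16.2%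

Compound 3 shows the lowest of the three numbers. Its nearest neighbour is compound 2, and that pair differs by a number 7 percentage points lower from compound 2 to compound 3 (within the scatter), a gap within the usual scatter, so the two cannot be ordered. The distance to compound 1 is large: a number 41.8 percentage points lower from compound 1 to compound 3 (beyond the scatter).

Compound 4 `CN(C)C(=O)c1cc2cnc(Nc3ccc(NC(=O)C4(C(=O)Nc5cccc(Br)c5)CC4)cc3)nc2n1C1CCCC1` is the bromo counterpart of compound 3: bromo in place of chloro on an aromatic carbon. Within the data shown here, two measured steps bear on this. Introducing a halogen onto the anilide ring cost heavily in both cases, a number 34.8 percentage points lower from compound 1 to compound 2 (beyond the scatter) and a number 41.8 percentage points lower from compound 1 to compound 3 (beyond the scatter), and the two halogenated compounds end up close to each other, a number 7 percentage points lower from compound 2 to compound 3 (within the scatter), within the scatter. Exchanging one halogen for another at the same aromatic carbon is therefore expected to give no step beyond the scatter in this assay, a number 1.8 percentage points higher from compound 3 to compound 4 (within the scatter). Compound 4 is estimated at 18%, with a range from 5% to 34%.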

Compound 4, percent growth inhibition at one concentration: 13.9%
Compound 4: the middle estimate sits 4.1 percentage points above what was measured, within the range that was stated.
By their numbers in this assay, from the lowest: compounds 4, 3 and 2 (each within the scatter of the next); then compound 1.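

In this assay, going from chloro to bromo at this carbon gives a number 2.3 percentage points lower from compound 3 to compound 4 (within the scatter), so this read-out does not tell the two halogens apart at this position. The earlier pair differed in both halogen and placement, whereas 3-bromophenyl in place of 4-bromophenyl now isolates placement alone and gives a number 9.3 percentage points lower from compound 2 to compound 4 (within the scatter), so the two bromo placements cannot be ordered either. The loss seen on adding a halogen to the anilide ring also holds for bromo at this carbon, with a number 44.1 percentage points lower from compound 1 to compound 4 (beyond the scatter), and compounds 2, 3 and 4 all stand well apart from compound 1.

No available evidence accounts for this loss. From the compounds shown here alone, whether a methyl group, a methoxy group or an amine at this carbon would also lower the reading, or would stay close to compound 1, remains open.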